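The source may hold more compounds than are shown below. What is called first, only, known or untested is meant among the compounds shown, and "the series" means these compounds.

Measured in a functional assay on L1210 cells (Mus musculus), read by MTT assay; on this read-out lower numbers stand for stronger inhibition and higher numbers for weaker inhibition:
compound 1 `CCC#C[C@@]1(O)[C@@H](CO)O[C@@H](n2ccc(N)nc2=O)[C@@H]1O` gives 129000 nM.
compound 3 `C=C[C@@]1(O)[C@@H](CO)O[C@@H](n2ccc(N)nc2=O)[C@@H]1O` gives 60800 nM.
compound 2 `C#C[C@@H]1[C@@H](O)[C@H](n2ccc(=O)[nH]c2=O)O[C@@H]1CO` gives only a limit of the assay, > 350000 nM.

Of the two numbers, compound 3 stands lowest, and compound 1 is its nearest neighbour, the gap being a 2.1-fold lower number from compound 1 to compound 3 (0.33 log units; beyond the scatter). Compound 4 `CC[C@@]1(O)[C@@H](CO)O[C@@H](n2ccc(N)nc2=O)[C@@H]1O` has not yet been measured. It differs from compound 3 in one place: ethyl in place of vinyl on a saturated ring carbon. For the measured compounds named here, the only measured step that bears on this change is the one on the same saturated ring carbon, a 2.1-fold lower number from compound 1 to compound 3 (0.33 log units; beyond the scatter), which was modest in size. A comparably small step in this assay is therefore expected here, possibly not beyond the scatter, with no clear direction. Compound 4 is estimated at 75000 nM, within a range from 25000 nM to 220000 nM, an expected step of a 1.2-fold higher number from compound 3 to compound 4 (0.09 log units; within the scatter).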

Compound 4, half-maximal inhibitory concentration: 269000 nM
The estimate for compound 4 lay 3.6-fold (0.55 log units) below the measured number, and the stated range ends below it.
By their numbers in this assay, from the lowest: compound 3; then compound 1; then compound 4. At a limit, above all of these: compound 2.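

In this assay ethyl in place of vinyl keeps the same count of carbons, yet the number clearly changes (a 4.4-fold higher number from compound 3 to compound 4 (0.65 log units; beyond the scatter)). Ethyl also compares poorly with but-1-yn-1-yl (a 2.1-fold higher number from compound 1 to compound 4 (0.32 log units; beyond the scatter)), so among these three compounds the two groups with a multiple bond give lower numbers than saturated ethyl. Nothing measured here explains this difference. From the compounds shown here alone, how a propyl chain or an amine on this saturated ring carbon would read remains open.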